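This account rests on a few compounds, and the source may have more. Where it says the series, first, only, none or still open, it means among the compounds named here.

Notes on the series. In a functional assay on DU-145 cells (Homo sapiens) for antiproliferative activity, read by MTT assay, with a stated time of 72 h (a lower number here means a stronger inhibitor, a higher number a weaker inhibitor), compound 1 `CC(C)(C)c1ccc(/C=C/C(=O)c2ccc(OCC(=O)N[C@H]3CCOC3=O)cc2)cc1` gives 6570 nM, the lowest of the two numbers recorded. Compound 3 `O=C1OCC[C@@H]1NC(=S)SCCOc1ccc([N+](=O)[O-])cc1` gives 31000 nM in this assay, a gap beyond the scatter. Compound 2 `Cc1cc(Cl)ccc1NCC(=O)N[C@H]1CCOC1=O` reaches only a limit of this assay, > 64000 nM. One of the three values in this assay sits at the limit of > 64000 nM in this assay, at which 1 of the 3 values shown sits. For the measured compounds named here, no two measured compounds differ in a single place, so no measured step is available to lean on. Compound 4 `O=C(COc1ccc(C(=O)/C=C/c2ccc(Cl)cc2Cl)cc1)N[C@H]1CCOC1=O` has not yet been measured; against compound 1 the change is 2,4-dichlorophenyl in place of 4-(tert-butyl)phenyl on a double-bonded chain carbon bound to a double-bonded chain carbon. Going by the values given here, with no measured step on such a change, the expected shift in this assay is a 1.3-fold lower number from compound 1 to compound 4 (0.12 log units; within the scatter), small and of uncertain direction, possibly within the scatter. Compound 4 is estimated at 5000 nM, between 1500 nM and 20000 nM.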

Compound 4, half-maximal inhibitory concentration: 8610 nM
Beside the measured number, compound 4's estimate is 1.7-fold (0.24 log units) below it; the measured number falls inside the stated range.
By their numbers in this assay, from the lowest: compounds 1 and 4 (each within the scatter of the next); then compound 3. At a limit, above all of these: compound 2.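

In this assay, for the compounds shown here, 2,4-dichlorophenyl in place of 4-(tert-butyl)phenyl on a double-bonded chain carbon bound to a double-bonded chain carbon gives a 1.3-fold higher number from compound 1 to compound 4 (0.12 log units; within the scatter), the only measured step. Going by these compounds alone, at this position the two substituted phenyl groups are therefore not told apart in this read-out, which the earlier compounds could not show. No available measurement bears on this step.

From the compounds shown here alone, whether a phenyl ring carrying an amine or a carboxylic acid at this position would give a similar number remains open. So does the effect of changing the lactone-bearing amide end of compound 1 while this position stays fixed.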